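The source may report more compounds than this note shows. Statements on the series, on what has been measured and on what is new or still open speak of the compounds shown alone.

Series notes. Compound 1 `O=C(NO)[C@H]1CCCCN1S(=O)(=O)N1CC=C(c2ccc(Br)cc2)CC1` and compound 2 `O=C(NO)[C@H]1CNCCN1S(=O)(=O)N1CC=C(c2ccc(F)cc2)CC1` share the hydroxycarbamoyl-bearing core and differ in the ring and the halogen. In a functional assay on MONO-MAC-6 cells (Homo sapiens) for inhibition (on this read-out higher numbers stand for weaker inhibition and lower numbers for stronger inhibition), compound 1 gives 1200 nM, and compound 2 gives 3560 nM, the higher of the two numbers and beyond the scatter of compound 1. Compound 3 `CN(C)S(=O)(=O)N1CCN(S(=O)(=O)N2CC=C(c3ccc(F)cc3)CC2)[C@@H](C(=O)NO)C1` is not yet measured; relative to compound 2 the change is dimethylsulfamoyl in place of hydrogen on an amine nitrogen in a ring. Within the data shown here, no measured pair shows this change, so the step from compound 2 to compound 3 is expected to be modest, most likely downward, with a 2.4-fold lower number from compound 2 to compound 3 (0.38 log units; beyond the scatter) as the estimate. For compound 3 the expected value is 1500 nM, in a range from 400 nM to 6000 nM.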

Compound 3, half-maximal inhibitory concentration: 250 nM
For compound 3 the middle estimate is 6.0-fold (0.78 log units) above the measured one; the whole stated range lies above it.
By their numbers in this assay, from the lowest: compound 3; then compound 1; then compound 2.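

On the amine nitrogen in the ring, three ring bonds from the ring atom that bears a large group, dimethylsulfamoyl in place of hydrogen gives a large step in this assay: a 14-fold lower number from compound 2 to compound 3 (1.15 log units; beyond the scatter). Among these compounds, this is the first single-place change, and it shows that this nitrogen accepts a substituent with a gain in inhibition rather than a loss. Nothing available explains the size of this step. Still open, as far as these compounds go, is whether a methyl or acetyl group on the same nitrogen gives a similar gain. A simple amide or a longer chain ending in a carboxylic acid there also remains untested in the compounds shown.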